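A few compounds are considered here, and "the series" means these few. Any claim that something is new, unique, unknown or untested is made for them only; others in the source may bear on it.

Measured so far in a functional assay on the whole organism (strain Kunming) with Mus musculus as the target, with a stated time of 0.5 h; on this read-out higher numbers stand for an effect only at larger amounts of compound and lower numbers for an effect already at smaller amounts

Compound 1 `COc1cc(OC)c(OC)cc1/C=C/COC(=O)/C=C/c1ccc(OC)c(OC)c1` gives 58.1 mg/kg
Compound 2 `COc1cc(OC)c(OC)cc1/C=C/COC(=O)/C=C/c1ccc(Br)cc1` gives 61.8 mg/kg
Compound 3 `COc1cc(OC)c(OC)cc1/C=C/COC(=O)/C=C/c1cccc(Br)c1` gives 75.7 mg/kg

Compound 3 (75.7 mg/kg) lies within the usual scatter of both other compounds. Compound 4 (`COc1cc(OC)c(OC)cc1/C=C/COC(=O)/C=C/c1ccccc1Cl`) carries 2-chlorophenyl in place of 3-bromophenyl on a double-bonded chain carbon bound to a double-bonded chain carbon. Three measured steps swap this same aromatic group: (a 1.1-fold higher number from compound 1 to compound 2 (0.03 log units; within the scatter)), (a 1.3-fold higher number from compound 1 to compound 3 (0.11 log units; within the scatter)) and (a 1.2-fold higher number from compound 2 to compound 3 (0.09 log units; within the scatter)). Each stays within the scatter. Among the compounds with values here, no measured compound carries 2-chlorophenyl, so these steps are only a loose guide. No step beyond the scatter is expected in this assay. The estimated step is small (a 1.2-fold lower number from compound 3 to compound 4 (0.07 log units; within the scatter)). For compound 4 the expected value is (65 mg/kg), with an estimated range from (40 mg/kg) to (105 mg/kg).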

Compound 4, dose for half-maximal effect: 58.7 mg/kg
For compound 4 the middle estimate is 1.1-fold (0.04 log units) above the measured one; the measured number falls inside the stated range.
By their numbers in this assay, from the lowest: compounds 1, 4, 2 and 3 (each within the scatter of the next).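

Adding 2-chlorophenyl at this place in this assay brings a chlorine-bearing ring into the set, and it stays within the scatter of all three earlier groups (a 1.3-fold lower number from compound 3 to compound 4 (0.11 log units; within the scatter); a 1.1-fold lower number from compound 2 to compound 4 (0.02 log units; within the scatter); a 1.0-fold higher number from compound 1 to compound 4 (0.00 log units; within the scatter)). The four aromatic groups on a double-bonded chain carbon bound to a double-bonded chain carbon therefore cannot be told apart by this read-out. Nothing available explains this result. Still open, going by these compounds, is whether any group at this place gives a step beyond the scatter, for example an amine, a carboxylic acid or a longer chain in place of the aromatic ring.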